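A few compounds are considered here, and "the series" means these few. Any claim that something is new, unique, unknown or untested is made for them only; others in the source may bear on it.

Measured compounds:
Compound 1 `Cc1nc(NC(C)(C)C)nc(N[C@@H]2C[C@H](CO)[C@@H](O)[C@H]2O)c1-c1nc2ccccc2s1` gives 2220 ng.h/mL in an ADME assay on the whole organism (plasma) for pharmacokinetics, with Rattus norvegicus as the target, with a stated time of 6 h, at a dose of 10 mg/kg by the oral route; on this read-out lower numbers stand for lower exposure and higher numbers for higher exposure at the dose given.
Compound 2 `Cc1nc(NCC(C)C)nc(N[C@@H]2C[C@H](CO)[C@@H](O)[C@H]2O)c1-c1nc2ccccc2s1` gives 1020 ng.h/mL in this assay.
Compound 3 `Cc1nc(NCCC(F)(F)F)nc(N[C@@H]2C[C@H](CO)[C@@H](O)[C@H]2O)c1-c1nc2ccccc2s1` gives 2560 ng.h/mL in this assay.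

Compound 2 stands lowest of the three on this read-out. The step of a 2.2-fold lower number from compound 1 to compound 2 (0.34 log units; beyond the scatter) sets it below compound 1, and the step of a 2.5-fold higher number from compound 2 to compound 3 (0.40 log units; beyond the scatter) sets it below compound 3, while a 1.2-fold higher number from compound 1 to compound 3 (0.06 log units; within the scatter) shows compounds 1 and 3 close to each other.

Compound 4 `Cc1nc(NCc2cccnc2)nc(N[C@@H]2C[C@H](CO)[C@@H](O)[C@H]2O)c1-c1nc2ccccc2s1` differs from compound 2 at the same place where compound 3 differs from it: pyridin-3-yl in place of isopropyl on a saturated chain carbon bound to a nitrogen on an aromatic ring

Among the measured compounds shown here, two measured steps bear on this change. Both alter the group on the nitrogen on the aromatic ring, and both end with compound 2 as the lower number: a 2.2-fold lower number from compound 1 to compound 2 (0.34 log units; beyond the scatter) read in reverse, and a 2.5-fold higher number from compound 2 to compound 3 (0.40 log units; beyond the scatter). Neither of them, however, introduces an aromatic ring at this place, so they say nothing direct about a pyridin-3-yl group there. Compound 4 is therefore expected to move upward from compound 2 in this assay by a modest amount at most, a 1.5-fold higher number from compound 2 to compound 4 (0.17 log units; within the scatter), with wide uncertainty. The estimate for compound 4 in this assay is 1500 ng.h/mL, within a range from 500 ng.h/mL to 4500 ng.h/mL.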

Compound 4, area under the concentration-time curve: 9.57 ng.h/mL
Compound 4: the middle estimate sits 160-fold (2.20 log units) above what was measured; measured number below the stated range.
By their numbers in this assay, from the lowest: compound 4; then compound 2; then compounds 1 and 3 (each within the scatter of the next).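

Exposure proved far more sensitive to the group at this place, on a saturated chain carbon bound to a nitrogen on an aromatic ring, than the earlier compounds had shown: in this assay, pyridin-3-yl in place of isopropyl brings a 110-fold lower number from compound 2 to compound 4 (2.03 log units; beyond the scatter). The drop does not rest on compound 2 as the only reference, since the other two compounds give a 270-fold lower number from compound 3 to compound 4 (2.43 log units; beyond the scatter) and a 230-fold lower number from compound 1 to compound 4 (2.37 log units; beyond the scatter), steps far larger than any among the three earlier compounds. Nothing measured here accounts for this drop.

The compounds shown leave open whether the loss belongs to the ring nitrogen or to any aromatic ring at this place, a question that a plain phenyl group would address. They also leave open how a cyclohexyl group, a saturated ring, would behave there.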